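The source may hold more compounds than are shown below. What is called first, only, known or untested is meant among the compounds shown, and "the series" means these compounds.

Measured in an assay on Sf9 cells for inhibition of protein deacetylase HDAC6 (Homo sapiens), read by fluorescence, with a stated time of 40 min, tested at 100 nM; on this read-out lower numbers stand for less inhibition and higher numbers for more inhibition at the one concentration tested (going by the name of the read-out):
compound 1 `O=C(NO)c1ccc(NCc2nc(-c3ccccc3)nn2-c2ccc(Br)cc2)cc1` — 65.9%
compound 2 `O=C(NO)c1ccc(NCc2nc(-c3ccccc3)nn2-c2ccccc2)cc1` — 72.6%

Within the data shown here, compound 2 and compound 1 sit within the scatter of each other; the single step, a number 6.7 percentage points higher from compound 1 to compound 2 (within the scatter), is the only comparison available. Compound 3 `Cc1cc(C)cc(-n2nc(-c3ccccc3)nc2CNc2ccc(C(=O)NO)cc2)c1` has not been measured. It differs from compound 2 by 3,5-dimethylphenyl in place of phenyl on an aromatic nitrogen. No measured step touches the group on that ring nitrogen, so the bromo-to-hydrogen step gives no guide here, and the series as a whole has shown no step beyond the scatter. For compound 3 in this assay the expected value is 70%, range 55% to 83%, with an expected step of a number 2.6 percentage points lower from compound 2 to compound 3 (within the scatter).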

Compound 3, a percentage reported as inhibition, at one concentration (the size of the read-out at that concentration, not a potency): 49.8%
The estimate for compound 3 lay 20.2 percentage points above the measured number, and the stated range ends above it.
By their numbers in this assay, from the lowest: compound 3; then compounds 1 and 2 (each within the scatter of the next).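

In this assay the aryl group on the aromatic nitrogen does move the number: 3,5-dimethylphenyl in place of phenyl gives a number 22.8 percentage points lower from compound 2 to compound 3 (beyond the scatter) and 3,5-dimethylphenyl in place of 4-bromophenyl gives a number 16.1 percentage points lower from compound 1 to compound 3 (beyond the scatter), whereas the bromo-to-hydrogen exchange at this group stayed within the scatter. Nothing measured bears on the reason for these steps.

Open, from the compounds shown here alone, is whether a single methyl group on that phenyl would give a comparable step or whether both are needed. Also open, going by these compounds, is how a methoxy group or a carboxylic acid on the same ring would read.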